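What replacing pyrimidin-5-yl might do to compound 3

The source may hold more compounds than are shown below. What is called first, only, known or untested is meant among the compounds shown, and "the series" means these compounds.

Compound 1 `CC(C)CN1C(=O)c2ccccc2[C@H](C(=O)Nc2ccc(F)c(C#N)c2)[C@H]1c1ccco1` gives 13000 nM
Compound 2 `CC(C)CN1C(=O)c2ccccc2[C@H](C(=O)Nc2ccc(F)c(C#N)c2)[C@H]1c1ccc(C(N)=O)s1` gives 19000 nM
Compound 3 `CC(C)CN1C(=O)c2ccccc2[C@H](C(=O)Nc2ccc(F)c(C#N)c2)[C@H]1c1cncnc1` gives 54000 nM

These compounds were tested in a physicochemical assay for solubility, in phosphate buffer, with a stated time of 18 h, at pH 7 (a lower number here means a less soluble compound, a higher number a more soluble compound), and differ only in the group on a saturated ring carbon of the shared core. Compound 3 stands highest of the three. The two steps up to it are modest but beyond the usual scatter: a 4.2-fold higher number from compound 1 to compound 3 (0.62 log units; beyond the scatter) and a 2.8-fold higher number from compound 2 to compound 3 (0.45 log units; beyond the scatter) are the ones that matter here. The remaining pair shows a 1.5-fold higher number from compound 1 to compound 2 (0.16 log units; within the scatter) and so no real separation.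

Compound 4 `CC(C)CN1C(=O)c2ccccc2[C@H](C(=O)Nc2ccc(F)c(C#N)c2)[C@H]1c1cnn(C)c1` carries 1-methyl-1H-pyrazol-4-yl in place of pyrimidin-5-yl on a saturated ring carbon. The entering ring is five-membered and aromatic, like the furan-2-yl of compound 1 and the 5-carbamoylthiophen-2-yl of compound 2, and both of those lie below compound 3 at 54000 nM in this small set. A modest fall is therefore expected, similar in size to a 2.8-fold higher number from compound 2 to compound 3 (0.45 log units; beyond the scatter) read backwards. The estimated change is a 2.2-fold lower number from compound 3 to compound 4 (0.33 log units; beyond the scatter) in the downward direction. For compound 4 the expected value is 25000 nM with an estimated range from 10000 nM to 60000 nM around it.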

Compound 4, solubility: 36000 nM
Compound 4: the middle estimate sits 1.4-fold (0.16 log units) below what was measured; measured number inside the range.
By their numbers in this assay, from the lowest: compounds 1, 2, 4 and 3 (each within the scatter of the next, the first and the last beyond it).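

In this assay, swapping pyrimidin-5-yl for the five-membered 1-methyl-1H-pyrazol-4-yl at this saturated ring carbon gives a 1.5-fold lower number from compound 3 to compound 4 (0.18 log units; within the scatter) and so does not clearly separate the two groups. The same holds against the 5-carbamoylthiophen-2-yl group, with a 1.9-fold higher number from compound 2 to compound 4 (0.28 log units; within the scatter) as the step, whereas the furan-2-yl group does separate, with a 2.8-fold higher number from compound 1 to compound 4 (0.44 log units; beyond the scatter) as the step; compound 4 therefore goes against any simple rule that five-membered rings here give a clearly lower number than pyrimidin-5-yl. Nothing measured here accounts for these differences.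

The compounds shown leave open how a plain phenyl ring, with no ring nitrogen, would compare with pyrimidin-5-yl at this carbon. They also leave open what a carboxylic acid or a dimethylamino group on the entering ring would do.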